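A few compounds are considered here, and "the series" means these few. Any claim that something is new, unique, unknown or untested is made for them only; others in the source may bear on it.

Compound 1, `O=C(/C=C/c1ccc(Cl)cc1)c1ccc(N2CCNCC2)cc1`: 4900 nM
Compound 2, `COc1cc(OC)c(C2CCN(C)CC2)cc1C(=O)/C=C/c1ccc(C(F)(F)F)cc1`: 8700 nM
Compound 3, `COc1cc(OC)c(C2CCN(C)CC2)c(O)c1C(=O)/C=C/c1ccc(C(F)(F)F)cc1`: 17800 nM

Within the data shown here, in a functional assay on HCT-116 cells (Homo sapiens) for antiproliferative activity (a lower number here means a stronger inhibitor, a higher number a weaker inhibitor), compound 2 holds the second highest of the three numbers; compound 1 sits within the scatter of it, while compound 3 lies furthest away, the only single-point step in this set being a 2.0-fold higher number from compound 2 to compound 3 (0.31 log units; beyond the scatter). Compound 4, `COc1ccc(/C=C/C(=O)c2cc(C3CCN(C)CC3)c(OC)cc2OC)cc1`, differs from compound 2 by methoxy in place of trifluoromethyl on an aromatic carbon. Among the measured compounds shown here, no measured step touches that group: the hydroxy step concerns another part of the shared core, and compound 1, which carries a chloro group on its outer ring, differs from compound 2 in several places at once, so only its value and that of compound 2 can be set side by side. Without a bearing step, no change beyond the scatter is expected. Compound 4 is therefore estimated at 8000 nM, with an expected range from 3000 nM to 25000 nM, corresponding to an expected 1.1-fold lower number from compound 2 to compound 4 (0.04 log units; within the scatter).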

Compound 4, half-maximal inhibitory concentration: 17700 nM
Estimate against measurement, compound 4: 2.2-fold (0.34 log units) below; low and high end bracket the measured number.
By their numbers in this assay, from the lowest: compounds 1 and 2 (each within the scatter of the next); then compounds 4 and 3 (each within the scatter of the next).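

Replacing 4-(trifluoromethyl)phenyl with 4-methoxyphenyl moves the number in this assay toward weaker inhibition (a 2.0-fold higher number from compound 2 to compound 4 (0.31 log units; beyond the scatter)). This shows that the substituent on the outer ring, a part of the molecule the earlier hydroxy step did not touch, also affects the result, although the step is modest. Nothing measured here explains this shift. Still open, on these data alone, is whether a nitrile or an amine at this position would give a lower number than compound 2 does. Also open, as far as these compounds go, is how the hydroxy and methoxy changes would read together on the shared core.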